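Removing a Trifluoromethyl Group from an Inactive Series

A few compounds are considered here, and "the series" means these few. Any claim that something is new, unique, unknown or untested is made for them only; others in the source may bear on it.

Three enaminone compounds sharing one core were tested in a functional assay on BT-474 cells (Homo sapiens) for cytotoxicity, read by MTT assay, with a stated time of 48 h; on this read-out lower numbers stand for stronger inhibition and higher numbers for weaker inhibition. Compound 1 `O=C(/C=C\Nc1ccc(F)cc1)c1nc(-c2ccc(C(F)(F)F)cc2)n2ccccc12` carries 4-fluorophenyl on the amine nitrogen; compound 1 gives only a limit of > 30000 nM in this assay. Compound 2 `O=C(/C=C\Nc1cnc2ccccc2c1)c1nc(-c2ccc(C(F)(F)F)cc2)n2ccccc12` carries quinolin-3-yl in place of 4-fluorophenyl on the amine nitrogen; compound 2 likewise gives a limit of > 30000 nM in this assay. Compound 3 `O=C(/C=C\Nc1ccc2cc[nH]c2c1)c1nc(-c2ccc(C(F)(F)F)cc2)n2ccccc12` carries 1H-indol-6-yl on the amine nitrogen; compound 3 also gives a limit of > 30000 nM in this assay. The steps between them therefore cannot be sized: a step that the two limits leave unreadable from compound 1 to compound 2, a step that the two limits leave unreadable from compound 1 to compound 3 and a step that the two limits leave unreadable from compound 2 to compound 3 all sit where the limit of > 30000 nM in this assay, at which 3 of the 3 values shown sit, hides them. Compound 2 thus stands, like the two others, at that limit with no number of its own.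

The step considered here leads from compound 2 to compound 4 `O=C(/C=C\Nc1cnc2ccccc2c1)c1nc(-c2ccccc2)n2ccccc12`, which differs by hydrogen in place of trifluoromethyl on an aromatic carbon. Among the measured compounds shown here, none of the measured steps touches this part of the molecule, and none of them is readable in size, so no measured step bears on it, and nothing suggests a move beyond the scatter in this assay. Compound 4 is therefore expected to remain at the limit, an estimated step that the limit leaves unreadable from compound 2 to compound 4, with a central estimate of 40000 nM and an expected range from 10000 nM to 150000 nM.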

Compound 4, half-maximal inhibitory concentration: 19700 nM
Estimate against measurement, compound 4: 2.0-fold (0.31 log units) above; the measured number falls inside the stated range.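

Among the compounds shown here, with hydrogen in place of trifluoromethyl, the series yields a measurable value for the first time: in this assay compound 4 gives 19700 nM, and it alone among the four compounds has a number of its own rather than a limit: the limit of > 30000 nM in this assay, at which 3 of the 4 values shown sit. For the compounds shown here, the earlier steps, all of them changes on the amine nitrogen, cannot be read, whereas the change from 4-(trifluoromethyl)phenyl to phenyl gives an at least 1.5-fold lower number from compound 2 to compound 4 (0.18 log units; that floor lies within the scatter) as the one readable step in the set. Since compound 2 has only a limit, this step is known only as a floor, so the data show that the position can carry a change with a readable outcome but do not fix how large that change is.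

From the compounds shown here alone, whether hydrogen at this aromatic carbon would also give a number with 4-fluorophenyl or 1H-indol-6-yl on the amine nitrogen remains open. Also open, going by these compounds, is how compound 4 would compare with analogues bearing a methoxy group, an amine or a carboxylic acid at the same carbon, and whether any such group would bring the value down further in this assay.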